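This account rests on a few compounds, and the source may have more. Where it says the series, first, only, none or still open, it means among the compounds named here.

Measured compounds in a physicochemical assay for solubility, read by HPLC, using the shake flask method, measured as kinetic solubility, with a stated time of 2 h, at pH 7.4; on this read-out lower numbers stand for lower solubility and higher numbers for higher solubility:
compound 1 `Cc1cc(NCc2ccccn2)n2nc(C)c(-c3ccc(F)cc3)c2n1`: < 5000 nM
compound 2 `Cc1ccc(-c2cnn3c(NCc4ccccn4)cc(C)nc23)cc1`: < 5000 nM
compound 3 `Cc1cc(NCc2ccccn2)n2nc(C)c(Nc3ccccc3)c2n1`: 7800 nM

The value of compound 2 in this assay is a limit of the assay, not a number. Compound 1 likewise gives only a limit in this assay. Going by the values given here, compound 3 is the one compound with a number, 7800 nM in this assay. Two of the three values sit at the limit (the limit of < 5000 nM in this assay, at which 2 of the 3 values shown sit).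

Compound 4 `Cc1cc(NCc2ccccn2)n2ncc(C3=CCOCC3)c2n1` is unmeasured. It differs from compound 2 by a group of 6 heavy atoms (5 carbon, 1 oxygen; one six-membered non-aromatic ring with 1 hetero atom) in place of a group of 7 heavy atoms (7 carbon; one six-membered aromatic ring of carbon only), on an aromatic carbon.

Among the compounds with values here, the only measured step is an at least 1.5-fold higher number from compound 1 to compound 3 (0.19 log units; that floor lies within the scatter), which exchanges one six-membered carbon-only aromatic ring for an anilino group on the same position of the shared core. The step from compound 2 to compound 4 also removes a six-membered carbon-only aromatic ring, but brings in a non-aromatic ring with one oxygen, so the measured step is only a loose guide.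

Compound 4 is expected to give 15000 nM in this assay, with a range of 5000 nM to 45000 nM. The expected step of an at least 3.0-fold higher number from compound 2 to compound 4 (0.47 log units; beyond the scatter) is estimated upward from the limit of compound 2, though a further limit read-out cannot be excluded.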

Compound 4, solubility: 171000 nM
The estimate for compound 4 lay 11-fold (1.06 log units) below the measured number; the measured number lies above the stated range.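

In this assay, the change from 4-methylphenyl to the six-membered non-aromatic ring with 1 hetero atom, on this aromatic carbon, gives an at least 34-fold higher number from compound 2 to compound 4 (1.53 log units; beyond the scatter). This position can thus move the read-out well beyond the scatter, which the earlier exchange of 4-fluorophenyl for anilino, with an at least 1.5-fold higher number from compound 1 to compound 3 (0.19 log units; that floor lies within the scatter), did not show. The true size of the new step stays a floor, because compound 2 gives only a limit: the limit of < 5000 nM in this assay, at which 2 of the 4 values shown sit.

The step removes the aromatic ring and brings in the ring oxygen together, and the compounds shown do not separate these two changes. On these data alone, whether a fully saturated tetrahydropyranyl ring, a piperidine amine or a carboxylic acid on this carbon would read the same remains open.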